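This account rests on a few compounds, and the source may have more. Where it says the series, first, only, none or still open, it means among the compounds named here.

Measured so far:
- Compound 1 `Cc1ccccc1-n1cc(-c2ccccc2NS(=O)(=O)c2c[nH]c(=O)[nH]c2=O)nn1` — 6550 nM
- Compound 2 `O=c1[nH]cc(S(=O)(=O)Nc2ccccc2-c2cn(-c3ccccc3F)nn2)c(=O)[nH]1` — 15300 nM
- Compound 3 `O=c1[nH]cc(S(=O)(=O)Nc2ccccc2-c2cn(-c3ccccc3Cl)nn2)c(=O)[nH]1` — 3170 nM

In a functional assay on OVCAR-3 cells (Homo sapiens) for antiproliferative activity, read by MTT assay, with a stated time of 24 h (on this read-out higher numbers stand for weaker inhibition and lower numbers for stronger inhibition), compound 2 gives the highest number of the three, so it is the weakest of this small set; compound 1 lies nearest to it and compound 3 furthest away. Compound 4 `O=c1[nH]cc(S(=O)(=O)Nc2ccccc2-c2cn(-c3ccc(Cl)cc3)nn2)c(=O)[nH]1` has not yet been measured. The change from compound 2 to compound 4 is 4-chlorophenyl in place of 2-fluorophenyl on an aromatic nitrogen. Two things move at once here: the halogen itself, and where on the phenyl ring the halogen sits, from the place it has in 2-fluorophenyl to the place it has in 4-chlorophenyl. The halogen swap alone is covered by the measured step of a 4.8-fold lower number from compound 2 to compound 3 (0.68 log units; beyond the scatter), and the two related steps of a 2.3-fold higher number from compound 1 to compound 2 (0.37 log units; beyond the scatter) and a 2.1-fold lower number from compound 1 to compound 3 (0.32 log units; beyond the scatter) point the same way, with the chloro compound giving the lowest number of the three. Among the compounds with values here, no measured pair shows what the changed place of the halogen does, so that part of the change stays open and the range has to be wide. A lower number than compound 2 is expected for compound 4, with compound 3 at 3170 nM as the nearest measured reference. For compound 4 the expected value is 4000 nM, in a range from 1300 nM to 12000 nM. This estimate corresponds to an expected step of a 3.8-fold lower number from compound 2 to compound 4 (0.58 log units; beyond the scatter).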

Compound 4, half-maximal inhibitory concentration: 1750 nM
The estimate for compound 4 lay 2.3-fold (0.36 log units) above the measured number, within the range that was stated.
By their numbers in this assay, from the lowest: compounds 4 and 3 (each within the scatter of the next); then compound 1; then compound 2.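

In this assay, within the data shown here, the place of the chlorine on the phenyl ring, which no earlier pair could show, makes no clear difference: the step is a 1.8-fold lower number from compound 3 to compound 4 (0.26 log units; within the scatter) and so 2-chlorophenyl and 4-chlorophenyl cannot be told apart here. The two larger steps, an 8.7-fold lower number from compound 2 to compound 4 (0.94 log units; beyond the scatter) and a 3.7-fold lower number from compound 1 to compound 4 (0.57 log units; beyond the scatter) as well, therefore read much like the earlier swaps to chloro, and a chlorine at either of these two places goes with lower numbers than the 2-fluorophenyl group of compound 2 and the 2-methylphenyl group of compound 1. No supporting measurement is available to explain why chloro stands apart from fluoro and methyl in this set.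

Going by these compounds, the place of the halogen has been compared for chlorine only, so it remains open whether 4-fluorophenyl or 4-methylphenyl would track their counterparts as closely as the two chloro compounds track each other. Also open, on these data alone, is how a phenyl ring carrying an amine or a carboxylic acid would behave, or a longer chain such as butyl in place of the phenyl ring on that aromatic nitrogen.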